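Amino acid amides in the oral tail flick test

A few compounds are considered here, and "the series" means these few. Any claim that something is new, unique, unknown or untested is made for them only; others in the source may bear on it.

Three compounds have numbers in a functional assay on the whole organism (Tail, strain ICR) with Mus musculus as the target, in the tail flick test, with a stated time of 120 min, at a dose of 25 umol/kg by the oral route; on this read-out lower numbers stand for a weaker effect and higher numbers for a stronger effect at the one dose given. Compound 1 `O=C(O)[C@@H]1CCCN1C(=O)CN(c1nc(Cl)nc2[nH]cnc12)C1CC1` gives 23.6%, compound 3 `CC[C@H](C)[C@H](NC(=O)CN(c1nc(Cl)nc2[nH]cnc12)C1CC1)C(=O)OCc1ccccc1` gives 22%, and compound 2 `N=C(N)NCCC[C@H](NC(=O)CN(c1ncnc2c1ncn2C1CCCCO1)C1CC1)C(=O)OCc1ccccc1` gives 38.2%. Compound 2 stands highest of the three, beyond the scatter from both compound 1 and compound 3, so on these numbers it is the strongest of the set. Compound 4 `O=C(CN(c1ncnc2c1ncn2C1CCCCO1)C1CC1)N[C@@H](CCC(=O)OCc1ccccc1)C(=O)OCc1ccccc1` has not yet been measured. Going by the values given here, it differs from compound 2 in one place: a group of 10 heavy atoms (8 carbon, 2 oxygen; one six-membered aromatic ring of carbon only) in place of a group of 5 heavy atoms (2 carbon, 3 nitrogen; no ring), on a saturated chain carbon, three bonds along the chain from an amide-type nitrogen and a carbonyl carbon No step between measured compounds is available, so the size of this change in this assay is unknown; a modest fall, about the edge of the scatter, is the working expectation. Compound 4 is estimated at 28%, with a range from 12% to 45%. The expected step is a number 10.2 percentage points lower from compound 2 to compound 4 (beyond the scatter).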

Compound 4, a percentage reported as activity, at one dose (the size of the read-out at that dose, not a potency): 20.7%
For compound 4 the middle estimate is 7.3 percentage points above the measured one; measured number inside the range.
By their numbers in this assay, from the lowest: compounds 4, 3 and 1 (each within the scatter of the next); then compound 2.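

In this assay, putting benzyloxycarbonyl in place of the group of 5 heavy atoms on the saturated chain carbon gives a number 17.5 percentage points lower from compound 2 to compound 4 (beyond the scatter). Going by these compounds alone, this is the first measured change at this position, and it shows that the read-out responds to what the position carries. No available measurement gives a reason for the fall.

As far as these compounds go, whether the fall follows from losing the group of 5 heavy atoms or from adding benzyloxycarbonyl remains open. A carboxylic acid, an amine or a longer carbon chain at the same carbon could help separate these two readings.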